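From pyrrolidin-1-yl to morpholin-4-yl on a sulfonyl sulfur

A few compounds are considered here, and "the series" means these few. Any claim that something is new, unique, unknown or untested is made for them only; others in the source may bear on it.

In a physicochemical assay for solubility, in phosphate buffer, measured as kinetic solubility, at pH 7.4, tested at 250 uM (a lower number here means a less soluble compound, a higher number a more soluble compound), compound 1 (`CCCCCCNc1ccc([N+](=O)[O-])cc1S(N)(=O)=O`) gives 6000 nM. Compound 2 (`CCCCCCCCNc1ccc([N+](=O)[O-])cc1S(N)(=O)=O`) gives < 1000 nM, which is a limit of the assay and not a number. Within the data shown here, compound 3 (`O=C(O)c1ccc(NCCCCCCCC(F)(F)F)c(S(=O)(=O)N2CCCC2)c1`) gives 66000 nM, the highest number so far and well clear of the number for compound 1. Compound 4 (`O=C(O)c1ccc(NCCCCCCCC(F)(F)F)c(S(=O)(=O)N2CCOCC2)c1`) differs from compound 3 in one place: morpholin-4-yl in place of pyrrolidin-1-yl on a sulfonyl sulfur. Among the measured compounds shown here, the only measured step, an at least 6.0-fold lower number from compound 1 to compound 2 (0.77 log units; beyond the scatter), lies on a saturated chain and not on the sulfonyl sulfur, so it offers no size to carry over. With nothing measured at this place, the expectation stays close to compound 3 at 66000 nM. The expected step in this assay is small and within the scatter, a 1.4-fold higher number from compound 3 to compound 4 (0.13 log units; within the scatter). For compound 4 the estimated value is 90000 nM, with an expected range from 35000 nM to 200000 nM.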

Compound 4, solubility: 244000 nM
Compound 4: the middle estimate sits 2.7-fold (0.43 log units) below what was measured; measured number outside the range, above it.
By their numbers in this assay, from the lowest: compound 1; then compound 3; then compound 4. At a limit, below all of these: compound 2.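

In this assay, among these compounds, this is the first measured change on the sulfonyl sulfur, and it is not a silent one: a 3.7-fold higher number from compound 3 to compound 4 (0.57 log units; beyond the scatter) comes with morpholin-4-yl in place of pyrrolidin-1-yl. Among the compounds shown here, the number moves clearly even though compound 3 already stood highest among the earlier compounds. Nothing shown gives a measured reason for this step.

Open, as far as these compounds go, is whether the ring oxygen of morpholin-4-yl matters, or whether piperidin-1-yl or an open-chain dimethylamino group on the sulfonyl sulfur would give a similar number. Also open, from the compounds shown here alone, is whether the same swap gives a similar step on the core of compound 1.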